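Compound 3 to compound 4: changing the benzyl substituent

This account rests on a few compounds, and the source may have more. Where it says the series, first, only, none or still open, it means among the compounds named here.

Measured in a functional assay on A2780 cells (Homo sapiens) for inhibition, read by MTT assay, with a stated time of 72 h; on this read-out lower numbers stand for stronger inhibition and higher numbers for weaker inhibition:
- Compound 1 `O=C1/C(=C\c2ccccc2)c2c(ncn2COCc2ccccc2)CCN1Cc1ccccc1` gives 20400 nM
- Compound 2 `Cc1ccc(CN2CCc3ncn(COCc4ccccc4)c3/C(=C/c3ccccc3)C2=O)cc1` gives 21200 nM
- Compound 3 `COc1ccc(CN2CCc3ncn(COCc4ccccc4)c3/C(=C/c3ccccc3)C2=O)cc1` gives 43100 nM

Compound 3 stands highest of the three, and both steps leading to it are modest: a 2.1-fold higher number from compound 1 to compound 3 (0.32 log units; beyond the scatter) and a 2.0-fold higher number from compound 2 to compound 3 (0.31 log units; beyond the scatter). Compound 4 `Cc1ccccc1CN1CCc2ncn(COCc3ccccc3)c2/C(=C/c2ccccc2)C1=O` is not yet measured. It differs from compound 3 by 2-methylphenyl in place of 4-methoxyphenyl on a saturated chain carbon bound to an amide-type nitrogen in a ring. Methyl on the aromatic ring changed nothing beyond the scatter in the one case seen, a 1.0-fold higher number from compound 1 to compound 2 (0.02 log units; within the scatter). For the measured compounds named here, no measured compound carries the 2-methylphenyl group, so this comparison is only a loose guide. A modest move to a lower number is therefore expected in this assay, roughly back towards compound 2 at 21200 nM. The expected step is a 1.8-fold lower number from compound 3 to compound 4 (0.25 log units; within the scatter). For compound 4 the estimated value is 24000 nM, with an expected range of 12000 nM to 46000 nM.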

Compound 4, half-maximal inhibitory concentration: 25300 nM
Estimate against measurement, compound 4: 1.1-fold (0.02 log units) below; the range from low to high includes it.
By their numbers in this assay, from the lowest: compounds 1, 2, 4 and 3 (each within the scatter of the next, the first and the last beyond it).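

In this assay, 2-methylphenyl in place of 4-methoxyphenyl gives a step that stays within the scatter (a 1.7-fold lower number from compound 3 to compound 4 (0.23 log units; within the scatter)), unlike the steps that led to compound 3. Moving the methyl around the ring also stays within the scatter (a 1.2-fold higher number from compound 2 to compound 4 (0.08 log units; within the scatter)), as does the methyl in place of hydrogen on the aromatic carbon (a 1.2-fold higher number from compound 1 to compound 4 (0.09 log units; within the scatter)). No measurement at hand accounts for these results.

The compounds shown leave open whether an amine or a carboxylic acid on this benzyl ring would shift the number further. They also leave open whether a 2-methoxyphenyl group would match compound 3 or compound 4.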